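Halogenated aryl urea analogues of a chloropyrazine benzylamine

This account rests on a few compounds, and the source may have more. Where it says the series, first, only, none or still open, it means among the compounds named here.

Compound 1 `Cc1cccc(NC(=O)Nc2cccc(CNc3nccnc3Cl)c2)c1` gives 11200 nM in a functional assay on HepG2 cells (Homo sapiens) for antiproliferative activity, read by MTT assay, with a stated time of 48 h (on this read-out higher numbers stand for weaker inhibition and lower numbers for stronger inhibition), the highest of the three numbers measured; compound 3 `CC(C)(C)c1ccc(NC(=O)Nc2cccc(CNc3nccnc3Cl)c2)cc1` gives 7550 nM and compound 2 `O=C(Nc1cccc(CNc2nccnc2Cl)c1)Nc1cccc(C(F)(F)F)c1` gives 6210 nM, both within the scatter of compound 1. Compound 4 `O=C(Nc1cccc(CNc2nccnc2Cl)c1)Nc1ccc(Cl)cc1Br` differs from compound 1 by 2-bromo-4-chlorophenyl in place of 3-methylphenyl on an amide-type nitrogen. Among the measured compounds shown here, the one step that bears on this change, a 1.8-fold lower number from compound 1 to compound 2 (0.26 log units; within the scatter), also alters the same aryl ring and stays within the scatter, and the pair of compound 1 and compound 3 shows the same picture. Compound 4 is therefore expected to give a number near compound 1 or somewhat lower, an estimated step of a 1.7-fold lower number from compound 1 to compound 4 (0.24 log units; within the scatter). Compound 4 is estimated at 6500 nM, expected between 2500 nM and 16000 nM.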

Compound 4, half-maximal inhibitory concentration: 6720 nM
Compound 4: middle estimate off by 1.0-fold (0.01 log units), on the low side; low and high end bracket the measured number.
By their numbers in this assay, from the lowest: compounds 2, 4, 3 and 1 (each within the scatter of the next).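

Bromine and chlorine now stand on the aryl ring, and in this assay 2-bromo-4-chlorophenyl in place of 3-methylphenyl on the amide-type nitrogen gives a 1.7-fold lower number from compound 1 to compound 4 (0.22 log units; within the scatter), so even this change leaves the number within the scatter. Across compounds 1, 2, 3 and 4, the four aryl groups at this place give numbers that cannot be told apart. Nothing given here accounts for this result.

From the compounds shown here alone, whether an amine or a carboxylic acid on this aryl ring would move the number beyond the scatter stays open. So does what bromine or chlorine does alone.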